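This account rests on a few compounds, and the source may have more. Where it says the series, first, only, none or still open, it means among the compounds named here.

Compound 1 `CC(C)n1c(S)nnc1Sc1nnc(-c2ccccc2)n1-c1ccccc1`, in a functional assay on HT-29 cells (Homo sapiens) for inhibition, read by MTT assay, with a stated time of 48 h; a higher number here means a weaker inhibitor, a lower number a stronger inhibitor: "not determined" (no result reported).
Compound 2 `CC(C)n1c(S)nnc1CSc1nnc(-c2ccccc2)n1-c1ccccc1`, in this assay: "not determined" (no result reported).
Compound 3 `Sc1nnc(Sc2nnc(-c3ccccc3)n2-c2ccccc2)n1-c1ccc(Cl)cc1`, in this assay: 38400 nM.

Compound 2 stands without a number: in this assay compound 2 has "not determined" (no result reported), and compound 1 is in the same position with "not determined" (no result reported). The only figure in the set belongs to compound 3, which in this assay gives 38400 nM, a weak result.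

The step from compound 2 leads to compound 4 `Fc1ccc(-n2c(S)nnc2CSc2nnc(-c3ccccc3)n2-c2ccccc2)cc1`. The structural change is 4-fluorophenyl in place of isopropyl on an aromatic nitrogen. Among the measured compounds shown here, because compound 2 carries no value, no step can be computed for this pair, and no other pair in the set shows how an isopropyl against a 4-fluorophenyl on that aromatic nitrogen shifts the result. For the measured compounds named here, the only anchor is compound 3, whose value in this assay, 38400 nM, comes from a compound that also bears an aryl group on the aromatic nitrogen. The size of the step is therefore unknown; it may lie within the scatter or beyond it in either direction.

On that basis compound 4 is expected to be a weak inhibitor in this assay, estimated at 30000 nM, with a range from 8000 nM to 110000 nM.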

Compound 4, half-maximal inhibitory concentration: 16700 nM
Compound 4: the middle estimate sits 1.8-fold (0.25 log units) above what was measured; the measured number falls inside the stated range.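

Compound 4 gives 16700 nM in this assay while compound 2 has "not determined" (no result reported) there, so no step can be read between them. The compounds shown leave open how 4-fluorophenyl in place of isopropyl on that aromatic nitrogen shifts the result. No evidence shown here bears on the value of compound 4.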